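Cyano and trifluoromethyl on the pendant phenyl ring

The compounds below may be only part of what the source reports. "The series", "measured", "known", "first", "only" and "open" are said of these compounds alone.

Compound 1 `CC/C(=C(/c1ccc(/C=C/C(=O)O)cc1)c1cc2ccccc2[nH]1)c1ccccc1C#N`: 9 nM
Compound 2 `CC/C(=C(/c1ccc(/C=C/C(=O)O)cc1)c1cc2ccccc2[nH]1)c1ccccc1C(F)(F)F`: 8 nM
Compound 3 `CC/C(=C(/c1ccc(/C=C/C(=O)O)cc1)c1cc2ccccc2[nH]1)c1ccc(C#N)cc1`: 278 nM

In a functional assay on MCF7 cells (Homo sapiens) for inhibition (on this read-out higher numbers stand for weaker inhibition and lower numbers for stronger inhibition), compound 1 gives 9 nM and compound 2 gives 8 nM. The two differ only in this change: trifluoromethyl in place of cyano on an aromatic carbon. The step is a 1.1-fold lower number from compound 1 to compound 2 (0.05 log units; within the scatter). Compound 3 carries a different core from compound 1, the difference being (4-cyanophenyl in place of 2-cyanophenyl on a double-bonded chain carbon bound to a double-bonded chain carbon and a saturated chain carbon); in this assay compound 3 gives 278 nM.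

Compound 4 `CC/C(=C(/c1ccc(/C=C/C(=O)O)cc1)c1cc2ccccc2[nH]1)c1ccc(C(F)(F)F)cc1` has not yet been measured. It differs from compound 3 by trifluoromethyl in place of cyano on an aromatic carbon. Within the data shown here, this is the same kind of change as the one from compound 1 to compound 2, not the same: there the place was ortho to a large group, here it is para to a large group. Resting on the step from compound 1 to compound 2 being a 1.1-fold lower number from compound 1 to compound 2 (0.05 log units; within the scatter), the author expects a step of about a 1.1-fold lower number from compound 3 to compound 4 (0.05 log units; within the scatter) from compound 3 to compound 4. For compound 4 the estimated value in this assay is 250 nM, with an expected range from 80 nM to 800 nM.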

Compound 4, half-maximal inhibitory concentration: 139 nM
Beside the measured number, compound 4's estimate is 1.8-fold (0.25 log units) above it, within the range that was stated.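

In this assay, trifluoromethyl in place of cyano gives a 2.0-fold lower number from compound 3 to compound 4 (0.30 log units; within the scatter), and the change reads alike on the two cores: the same change on two cores in this assay, a 1.1-fold lower number (0.05 log units; within the scatter) from compound 1 to compound 2 and a 2.0-fold lower number (0.30 log units; within the scatter) from compound 3 to compound 4, 1.8-fold (0.25 log units) apart, within the scatter of two such steps. The steps that change the core are larger, with a 17-fold higher number from compound 2 to compound 4 (1.24 log units; beyond the scatter) and a 15-fold higher number from compound 1 to compound 4 (1.19 log units; beyond the scatter), so the choice of core, not the exchange of these two groups, accounts for the large differences among these compounds. Among these compounds, this rests on only two pairs, both within the scatter, so it does not show that a step beyond the scatter would carry over, or that this one would hold on other cores.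

The compounds shown leave open how an amine or a methoxy group in place of cyano would behave on either core.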